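Pyridinyl for pyrimidinyl in a weakly active aryl amine set

The source may report more compounds than this note shows. Statements on the series, on what has been measured and on what is new or still open speak of the compounds shown alone.

Three compounds have numbers in a functional assay on PC-3 cells (Homo sapiens) for antiproliferative activity, read by CCK-8 assay, with a stated time of 6 days; on this read-out higher numbers stand for weaker inhibition and lower numbers for stronger inhibition. Compound 1 `Cn1nccc1-c1cccc2c1CCCN2c1ccc(C#N)c(C(F)(F)F)c1` gives 9800 nM and compound 3 `N#Cc1ccc(N2CCc3cc(-c4cnc5ccccc5c4)ccc3C2)cc1C(F)(F)F` gives 25100 nM. Compound 2 `CCN(c1ccc(C#N)c(Cl)c1)c1cc(-c2cncnc2)ccc1C` is reported in this assay only as a limit, > 30000 nM, and not as a measured number; this is the limit of > 30000 nM in this assay, at which 1 of the 3 values shown sits. For the measured compounds named here, no two measured compounds differ in a single place, so nothing within the set calibrates the size of a one-ring swap, and the three values share no common core that would allow a step to be read across them.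

Compound 4 `CCN(c1ccc(C#N)c(Cl)c1)c1cc(-c2cccnc2)ccc1C` differs from compound 2 by pyridin-3-yl in place of pyrimidin-5-yl on an aromatic carbon. Since compound 2 sits at a limit, the starting point of the step is itself uncertain, and no comparable exchange is available to suggest a direction. The step from compound 2 to compound 4 is therefore expected to be an at least 1.0-fold lower number from compound 2 to compound 4 (0.02 log units; that floor lies within the scatter), within the usual scatter. Compound 4 is expected to give about 28000 nM, in the range 9000 nM to 70000 nM, with a fair chance that this assay again returns only a limit.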

Compound 4, half-maximal inhibitory concentration: 11000 nM
Compound 4: middle estimate off by 2.5-fold (0.41 log units), on the high side; the range from low to high includes it.
By their numbers in this assay, from the lowest: compounds 1 and 4 (each within the scatter of the next); then compound 3. At a limit, above all of these: compound 2.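

In this assay, for the compounds shown here, pyridin-3-yl in place of pyrimidin-5-yl gives the first step that can be read: an at least 2.7-fold lower number from compound 2 to compound 4 (0.43 log units; beyond the scatter). This aromatic carbon, para to a methyl group, therefore tolerates a change of ring atoms that keeps the six-membered aromatic ring and its heavy-atom count, and the change moves compound 4 to a measured number, 11000 nM. The step is a floor and not a full size, since compound 2 stands at a limit: the limit of > 30000 nM in this assay, at which 1 of the 4 values shown sits.

Open, on these data alone, is how a phenyl ring, with no ring nitrogen, or a pyridin-4-yl group would read at this same carbon. Also open, as far as these compounds go, is whether the exchange of pyrimidin-5-yl for pyridin-3-yl would carry over to the core of compound 1 or the core of compound 3.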